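The source may report more compounds than this note shows. Statements on the series, on what has been measured and on what is new or still open speak of the compounds shown alone.

Compounds measured in a functional assay on A549 cells (Homo sapiens) for cytotoxicity, read by MTT assay, with a stated time of 72 h; on this read-out higher numbers stand for weaker inhibition and lower numbers for stronger inhibition:
compound 1 `Cc1cc(=O)n(-c2cccc(F)c2)nc1C(=O)Nc1ccc(Oc2ncnc3c2ccn3C)cc1`: 23400 nM
compound 2 `Cc1ccc(-n2nc(C(=O)Nc3ccc(Oc4ncnc5c4ccn5C)cc3)c(C)cc2=O)cc1`: > 60000 nM, a limit of the assay
compound 3 `Cc1cc(=O)n(-c2ccccc2C(F)(F)F)nc1C(=O)Nc1ccc(Oc2ncnc3c2ccn3C)cc1`: 5860 nM

Compound 3 stands lowest of the two numbers obtained in this assay, with compound 1 nearest at a higher number. The value of compound 2 is a limit only (the limit of > 60000 nM in this assay, at which 1 of the 3 values shown sits). The measured steps are a 4.0-fold lower number from compound 1 to compound 3 (0.60 log units; beyond the scatter), an at least 2.5-fold higher number from compound 1 to compound 2 (0.40 log units; beyond the scatter) and an at least 10-fold lower number from compound 2 to compound 3 (1.01 log units; beyond the scatter); all three change the aryl group on the aromatic nitrogen and nothing else.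

Compound 4 `Cc1cc(=O)n(-c2ccccc2C(F)(F)F)nc1C(=O)Nc1ccc(Oc2ncnc3c2ccn3C)c(F)c1` differs from compound 3 by fluoro in place of hydrogen on an aromatic carbon, ortho to a large group and meta to a large group. Among the compounds with values here, none of the measured steps touches this position, so none bears directly on the change; the aryl on the aromatic nitrogen is held the same as in compound 3. The expectation in this assay is therefore a step within the scatter, in no particular direction. Compound 4 is expected at 5500 nM, with a range from 1500 nM to 18000 nM. The step this estimate means, a 1.1-fold lower number from compound 3 to compound 4 (0.03 log units; within the scatter), is expected to stay within the scatter.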

Compound 4, half-maximal inhibitory concentration: 35400 nM
Beside the measured number, compound 4's estimate is 6.4-fold (0.81 log units) below it; the measured number lies above the stated range.
By their numbers in this assay, from the lowest: compound 3; then compounds 1 and 4 (each within the scatter of the next). At a limit, above all of these: compound 2.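

On an aromatic carbon ortho to a large group and meta to a large group, fluoro in place of hydrogen gives a 6.0-fold higher number from compound 3 to compound 4 (0.78 log units; beyond the scatter) in this assay, a shift toward weaker inhibition from the entry of a single heavy atom. Within the data shown here, the earlier steps all changed the aryl group on the aromatic nitrogen, so this is the first sign that the number also responds to a change at this separate position on the carbon-only ring. Nothing measured here accounts for the step.

On these data alone, whether the shift belongs to fluoro alone or would also follow from chloro, methoxy or an amine at this position remains open. Also open, as far as these compounds go, is whether the same change would act similarly with 3-fluorophenyl or 4-methylphenyl on the aromatic nitrogen in place of 2-(trifluoromethyl)phenyl.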